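Working notes on a urea series, compound 4 still unmeasured

The source may report more compounds than this note shows. Statements on the series, on what has been measured and on what is new or still open speak of the compounds shown alone.

Measured so far in a functional assay on RS4-11 cells (Homo sapiens) for inhibition, read by CCK-8 assay, with a stated time of 48 h; on this read-out lower numbers stand for stronger inhibition and higher numbers for weaker inhibition:
compound 1, `COc1ccc(Oc2ccc([N+](=O)[O-])cc2-c2ccsc2S(=O)(=O)N2CCN(C(=S)Nc3ccc([N+](=O)[O-])cc3)CC2)cc1OC`, gives only a limit, > 50000 nM.
compound 2, `O=C(NCCNS(=O)(=O)c1ccc(-c2ccccc2OCc2ccccc2)s1)Nc1cc(Cl)cc(Cl)c1`, gives only a limit, > 20000 nM.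
compound 3, `O=C(NCCNS(=O)(=O)c1ccc(-c2ccccc2O[C@H]2CC[C@@H](O)CC2)s1)Nc1cc(C(F)(F)F)cc(C(F)(F)F)c1`, gives 9300 nM.

Among the compounds with values here, compound 3 thus holds the only numerical value of the three; the other two sit at limits, one at the limit of > 20000 nM in this assay, at which 1 of the 3 values shown sits, and one at the limit of > 50000 nM in this assay, at which 1 of the 3 values shown sits. Within the data shown here, nothing measured here isolates a single change, so no measured step is available.

Compound 4, `O=C(NCCNS(=O)(=O)c1ccc(-c2ccccc2OCc2cccc(O)c2)s1)Nc1cc(C(F)(F)F)cc(C(F)(F)F)c1`, differs from compound 3 in one place: 3-hydroxybenzyl in place of 4-hydroxycyclohexyl on an oxygen on an aromatic ring. Among the measured compounds shown here, with no measured step to lean on, the expected change in this assay is none beyond the usual scatter, a step estimated as a 1.1-fold higher number from compound 3 to compound 4 (0.03 log units; within the scatter). In this assay compound 4 is therefore expected at about 10000 nM, within 3000 nM to 35000 nM.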

Compound 4, half-maximal inhibitory concentration: 3000 nM
For compound 4 the middle estimate is 3.3-fold (0.52 log units) above the measured one; the measured number falls inside the stated range.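

In this assay, the substituent on an oxygen on an aromatic ring affects the read-out: 3-hydroxybenzyl in place of 4-hydroxycyclohexyl gives a 3.1-fold lower number from compound 3 to compound 4 (0.49 log units; beyond the scatter). Within the data shown here, this is the first measured single change, and it is a modest one. Nothing shown accounts for the step. Whether the gain comes from the aromatic ring or depends on its hydroxyl stays open, as the compounds shown include no matched pair that separates the two. An unsubstituted benzyl, or a 3-aminobenzyl or 3-carboxybenzyl group on the same oxygen, would address this.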